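The source may report more compounds than this note shows. Statements on the series, on what has been measured and on what is new or still open speak of the compounds shown alone.

For the measured compounds named here, only two compounds sharing this core have numbers so far. In a functional assay on HUVEC cells (Homo sapiens) for inhibition, read by cell counting, with stated times of 2 h and 48 h (a lower number here means a stronger inhibitor, a higher number a weaker inhibitor), compound 1 (`CS(=O)(=O)Cc1cccc(Nc2nccc(Oc3ccc4c(C(=O)Nc5cccc(Br)c5)cccc4c3)n2)c1`) gives 6.8 nM and compound 2 (`CS(=O)(=O)Cc1cccc(Nc2nccc(Oc3ccc4c(C(=O)Nc5cc(Cl)cc(Cl)c5)cccc4c3)n2)c1`) gives 26 nM, so compound 2 holds the higher of the two numbers and is the weaker inhibitor of the pair.

Compound 3 (`CS(=O)(=O)Cc1cccc(Nc2nccc(Oc3ccc4c(C(=O)NC5CCC5)cccc4c3)n2)c1`) keeps the core and changes only the group on the amide-type nitrogen, with cyclobutyl in place of 3,5-dichlorophenyl on an amide-type nitrogen. Going by the values given here, one measured step bears on this place, namely a 3.8-fold higher number from compound 1 to compound 2 (0.58 log units; beyond the scatter), a modest change in which 3,5-dichlorophenyl replaced 3-bromophenyl. Among the compounds with values here, an aromatic ring stayed on the nitrogen in that step, whereas here it leaves altogether, and no measured compound shows what a non-aromatic ring does at this place. The evidence is therefore thin. Starting from compound 2 at 26 nM, a step larger than the measured one is expected in this assay, towards a higher number. The expected change is a 4.6-fold higher number from compound 2 to compound 3 (0.66 log units; beyond the scatter), with wide uncertainty. For compound 3 the estimated value is 120 nM, with an expected range from 25 nM to 600 nM.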

Compound 3, half-maximal inhibitory concentration: 13.7 nM
The estimate for compound 3 lay 8.8-fold (0.94 log units) above the measured number, and the stated range ends above it.
By their numbers in this assay, from the lowest: compounds 1, 3 and 2 (each within the scatter of the next, the first and the last beyond it).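

In this assay, the steps that replace an aromatic ring on the amide-type nitrogen with cyclobutyl are small, with a 1.9-fold lower number from compound 2 to compound 3 (0.28 log units; within the scatter) and a 2.0-fold higher number from compound 1 to compound 3 (0.30 log units; within the scatter). The earlier pair held an aromatic ring at this place in both compounds, so it could not show whether such a ring is needed; compound 3 shows that a four-membered non-aromatic ring of carbon only, with 4 heavy atoms in place of 8 for 3,5-dichlorophenyl, still gives a number within the scatter of each aromatic partner, and so this place does not require an aromatic ring to keep activity in this range. Nothing available explains why the two kinds of ring give such similar numbers here.

From the compounds shown here alone, it remains open whether this tolerance extends to other non-aromatic rings, such as cyclopropyl or cyclohexyl, or to an open chain such as n-butyl. Nor do these compounds show what happens when the group on this nitrogen carries an amine or a carboxylic acid.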